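Amide variation on the shared core and cell tolerance

The source may report more compounds than this note shows. Statements on the series, on what has been measured and on what is new or still open speak of the compounds shown alone.

Compound 1 `CCC(=O)Nc1ncc(-c2ccc(OC)cc2)n1C` is known in a toxicity assay on THP-1 cells (Homo sapiens) for inhibition (a higher number here means that more compound is tolerated, a lower number that less compound is tolerated), only as a limit of the assay, > 100000 nM. Compound 3 `COc1ccc(-c2cnc(NC(=O)c3ccc(F)cc3)n2C2CCCC2)cc1` likewise reports only a limit in this assay, > 100000 nM. Compound 2 `Cn1c(-c2ccc(Cl)cc2)cnc1NC(=O)c1ccc(F)cc1` gives a number in this assay, 37000 nM. Two of the three results sit at the limit (the limit of > 100000 nM in this assay, at which 2 of the 3 values shown sit). Compound 4 `COc1ccc(-c2cnc(NC(=O)c3ccccc3F)n2C)cc1` differs from compound 1 by 2-fluorophenyl in place of ethyl on a carbonyl carbon. Going by the values given here, no measured pair isolates this change; compound 3 carries a fluorophenyl amide and stays at the limit, compound 2 carries a fluorophenyl amide and gives a number. For compound 4 the expected step is an at least 1.2-fold lower number from compound 1 to compound 4 (0.09 log units; that floor lies within the scatter), likely none beyond scatter, with a fair chance of another limit. Compound 4 is estimated at 80000 nM, range 30000 nM to 200000 nM.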

Compound 4, half-maximal cytotoxic concentration: > 100000 nM
Compound 4: no number, only a limit (the forecaster's own chance of this, stated with the estimate: 50%); middle value at least 1.2-fold (0.09 log units) from the limit.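

Going by these compounds alone, compound 1 and compound 4 both give only a limit in this assay, and no step between them can be read. The compounds shown leave open whether 2-fluorophenyl in place of ethyl on a carbonyl carbon changes cell tolerance at all.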